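Methyl for hydrogen on the benzylidene phenyl: next step

The source may hold more compounds than are shown below. What is called first, only, known or untested is meant among the compounds shown, and "the series" means these compounds.

Of the compounds shown here, two carry numbers so far. Compound 1 `Cc1ccc(N(C)CC2CCC/C(=C\c3ccccc3)C2(O)c2ccccc2)cc1` gives 64.2% in a functional assay on the whole organism (strain Kunming) for inhibition, with Mus musculus as the target, in the writhing test, with stated times of 1 h and 15 min, at a dose of 200 mg/kg by the oral route; on this read-out higher numbers stand for more inhibition at the one dose given (going by the name of the read-out) and lower numbers for less inhibition. Compound 2 `COc1ccc(C2(O)/C(=C/c3ccccc3)CCCC2CN(C)c2ccc(C)cc2)cc1` gives 78.7% in this assay. Among the compounds with values here, the one measured step, a number 14.5 percentage points higher from compound 1 to compound 2 (beyond the scatter), is a methoxy in place of hydrogen on an aromatic carbon. On the two numbers at hand, compound 2 stands highest, its nearest neighbour being compound 1 at a step beyond the scatter.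

Compound 3 `COc1ccc(C2(O)/C(=C/c3ccc(C)cc3)CCCC2CN(C)c2ccc(C)cc2)cc1` differs from compound 2 by methyl in place of hydrogen on an aromatic carbon; cut one bond further out, the change reads phenyl to 4-methylphenyl. Within the data shown here, no measured step touches this ring or this group, so the step from compound 1 to compound 2, though modest and beyond the scatter, bears on it only as a sign that a small substituent on an aromatic carbon can shift this read-out without being large. With nothing closer to go on, the expectation for this assay is a step of a number 0.7 percentage points lower from compound 2 to compound 3 (within the scatter), which is expected to stay within the scatter. Compound 3 is therefore estimated at 78%, with a range from 60% to 92%.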

Compound 3, a percentage reported as inhibition, in the whole organism at one dose (the size of the read-out at that dose, not a potency): 62.2%
Compound 3: the middle estimate sits 15.8 percentage points above what was measured, and the stated range covers the measured number.
By their numbers in this assay, from the lowest: compounds 3 and 1 (each within the scatter of the next); then compound 2.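

The change of phenyl to 4-methylphenyl gives a number 16.5 percentage points lower from compound 2 to compound 3 (beyond the scatter) in this assay, so this ring, which the earlier step did not touch, responds to the addition of a single methyl. The earlier step, a number 14.5 percentage points higher from compound 1 to compound 2 (beyond the scatter), raised the number with a methoxy on a different aromatic ring, while this one lowers it with a methyl, so across these two steps a small group on an aromatic carbon does not move the read-out in one fixed direction. Nothing in hand accounts for the lower number of compound 3, and the step stands as an observation only.

On these data alone, a single methyl at this place cannot show whether any group there lowers the number or only this one, so the outcome with a methoxy, a fluorine, an ethyl chain or an amine on the same carbon stays open. Also open, as far as these compounds go, is whether the methyl step would hold without the methoxy on the other ring, since here it is read only with that methoxy present and at one dose.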